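Swapping the amide-nitrogen chain of compound 2 for a ring

The source may report more compounds than this note shows. Statements on the series, on what has been measured and on what is new or still open speak of the compounds shown alone.

Measured compounds:
compound 1 `COc1c(C)cnc(CN2c3nc(N)nc(Cl)c3NC(=O)[C@@H]2C)c1C` with 940 nM
compound 2 `COc1c(C)cnc(CN2CC(=O)N(CCCC(C)C)c3c(Cl)nc(N)nc32)c1C` with 3110 nM
compound 3 `COc1ccnc(CN2CC(=O)N(CC(C)C)c3c(Cl)nc(N)nc32)c1OC` with 100 nM

Of the compounds shown here, three sharing a common core have been tested in a functional assay on MCF7 cells (Homo sapiens) for inhibition; a higher number here means a weaker inhibitor, a lower number a stronger inhibitor. Compound 1 gives 940 nM, compound 2 gives 3110 nM, and compound 3 gives 100 nM. Compound 2 stands at the highest number of the three, and its gaps to compound 1 and to compound 3 both lie beyond the usual scatter, so among these three it is the weakest inhibitor. Among the measured compounds shown here, the compound closest to it in number is compound 1; the one furthest away is compound 3.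

Compound 4 `COc1c(C)cnc(CN2CC(=O)N(C3CCCC3)c3c(Cl)nc(N)nc32)c1C` has not yet been measured in this assay. It differs from compound 2 in one place: cyclopentyl in place of 4-methylpentyl on an amide-type nitrogen in a ring. For the measured compounds named here, no step between two measured compounds isolates this kind of change, so the expectation rests on the wider picture. Compound 3, which carries the smaller isobutyl group on the same amide-type nitrogen, gives the lowest number of the three, while compound 2 with the longer 4-methylpentyl group gives the highest, although compound 3 also differs elsewhere.

The step from compound 2 to compound 4 is therefore expected to lower the number, a 2.6-fold lower number from compound 2 to compound 4 (0.41 log units; beyond the scatter), though with wide uncertainty. Compound 4 is estimated at 1200 nM, within a range of 400 nM to 3600 nM.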

Compound 4, half-maximal inhibitory concentration: 820 nM
Beside the measured number, compound 4's estimate is 1.5-fold (0.17 log units) above it; measured number inside the range.
By their numbers in this assay, from the lowest: compound 3; then compounds 4 and 1 (each within the scatter of the next); then compound 2.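

In this assay, among the compounds shown here, putting cyclopentyl in place of 4-methylpentyl on the amide-type nitrogen gives a 3.8-fold lower number from compound 2 to compound 4 (0.58 log units; beyond the scatter), the first step here that changes this position and nothing else. It shows that the group on this nitrogen can by itself move the number beyond the scatter, and that, for this pair, the ring goes with the stronger inhibition. Both groups are made of carbon only, with no hydrogen-bond donors or acceptors and no net charge, and nothing available explains why the number falls.

This single step cannot separate the effect of having a ring from that of losing the longer open chain, so it remains unclear which of the two matters; a shorter chain such as n-butyl and a larger ring such as cyclohexyl, each on the same nitrogen, would tell these apart. Also open, from the compounds shown here alone, is how this position responds to a group that is not pure carbon, such as a tetrahydrofuranyl ring or a chain ending in an amine.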